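The source may report more compounds than this note shows. Statements on the series, on what has been measured and on what is new or still open speak of the compounds shown alone.

Working notes on the series.

Compound 1, `CCCN(C)c1nc(Cc2c(F)cccc2F)c(C)c(=O)[nH]1`, in an ADME assay on MT4 cells (Homo sapiens) for cytotoxicity, read by MTT assay, with a stated time of 4 days (on this read-out lower numbers stand for higher toxicity in this test and higher numbers for lower toxicity in this test), gives a value that is a limit of the assay, > 81000 nM. Compound 2, `CCCN(CCC)c1nc(Cc2c(F)cccc2F)c(C)c(=O)[nH]1`, in this assay likewise gives only a limit, > 74000 nM. The change from compound 1 to compound 2 is ethyl in place of hydrogen on a saturated chain carbon bound to a nitrogen on an aromatic ring. The step that the two limits leave unreadable from compound 1 to compound 2 cannot be read as a size because the limit of > 74000 nM in this assay, at which 1 of the 3 values shown sits, and the limit of > 81000 nM in this assay, at which 1 of the 3 values shown sits, are all that is known at its two ends.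

Within the data shown here, compound 3, `CC(c1cc(=O)[nH]c(N(C)C)n1)c1c(F)cccc1F`, is the one member with a number rather than a limit in this assay: compound 3 gives 89000 nM. The difference between the core of compound 3 and the core of compound 1 is not broken down here. Compound 4, `CCCN(C)c1nc(C(C)c2c(F)cccc2F)cc(=O)[nH]1`, has not yet been measured in this assay; its change from compound 3 is ethyl in place of hydrogen on a saturated chain carbon bound to a nitrogen on an aromatic ring, the same change as that from compound 1 to compound 2, made at the same place.

Since the measured pair gives no readable size for this change, the expectation for compound 4 rests on the closeness of all three values to the upper end of the test range. Compound 3 sits at 89000 nM, and compound 4 is expected to stay in that region. The expected step is a 1.0-fold lower number from compound 3 to compound 4 (0.02 log units; within the scatter), within the scatter. Compound 4 is estimated at 85000 nM, with the range 40000 nM to 160000 nM, and a real chance that only a limit is reported.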

Compound 4, half-maximal cytotoxic concentration: > 81000 nM
Compound 4: a limit, no number (the forecaster's own chance of this, stated with the estimate: 45%); the middle value lies beyond the limit too.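

Among these compounds, compound 4 gives only a limit in this assay, > 81000 nM, so no size can be read for the change from compound 3 to compound 4, and no new step comes from this result. The compounds shown leave open where the true values of compound 1, compound 2 and compound 4 lie, and whether ethyl in place of hydrogen at this place alters the read-out at all.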